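A few compounds are considered here, and "the series" means these few. Any claim that something is new, unique, unknown or untested is made for them only; others in the source may bear on it.

Values in a functional assay on Caco-2 cells (Homo sapiens), read by MTT assay, with a stated time of 48 h; on this read-out higher numbers stand for weaker inhibition and lower numbers for stronger inhibition:
- Compound 1 `CCN(CC)CCNC(=O)c1ccc(C(CC)(CC)c2ccc(OCC(O)C(C)(C)C)c(C)c2)n1CC`: 2310 nM
- Compound 2 `C#CC(C)OC(=O)c1ccc(C(CC)(CC)c2ccc(OCC(O)C(C)(C)C)c(C)c2)n1CC`: > 50000 nM

As far as these compounds go, compound 2 gives > 50000 nM, which is a limit of this assay and not a number, so its true position is unknown. Compound 3 `CCn1c(C(=O)OCc2ccc(F)cc2)ccc1C(CC)(CC)c1ccc(OCC(O)C(C)(C)C)c(C)c1` carries 4-fluorobenzyl in place of 1-methylprop-2-yn-1-yl on an oxygen next to a carbonyl group.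

For the measured compounds named here, no measured step covers this exchange. The nearest is an at least 21-fold higher number from compound 1 to compound 2 (1.33 log units; beyond the scatter), a large step at the same carbonyl carbon, with (1-methylprop-2-yn-1-yl)oxy replacing (2-(diethylamino)ethyl)amino. Compound 3 also lacks the (2-(diethylamino)ethyl)amino group, so weak inhibition is expected on the strength of an at least 21-fold higher number from compound 1 to compound 2 (1.33 log units; beyond the scatter), which is a single example. A large change from this exchange alone is not expected, and any measurable value would mean a modest move toward lower numbers. A further reading at the limit is about as likely as a number.

The estimate for compound 3 is 40000 nM, with an expected range from 12000 nM to 90000 nM. The expected change is an at least 1.2-fold lower number from compound 2 to compound 3 (0.09 log units; that floor lies within the scatter).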

Compound 3, half-maximal inhibitory concentration: > 50000 nM
Compound 3: only a limit was reported (the forecaster's own chance of this, stated with the estimate: 55%); middle value at least 1.2-fold (0.09 log units) away from the limit.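

In this assay compound 3 gives > 50000 nM, which is a limit of the assay and not a number. Replacing (2-(diethylamino)ethyl)amino with (4-fluorobenzyl)oxy on the carbonyl carbon gives an at least 21-fold higher number from compound 1 to compound 3 (1.33 log units; beyond the scatter), so a second group on the oxygen, this one carrying a six-membered aromatic ring, goes with the same large step as 1-methylprop-2-yn-1-yl, and among the compounds shown only compound 1 keeps a readable number. No order can be set between the 4-fluorobenzyl and 1-methylprop-2-yn-1-yl groups, and the step between compound 2 and compound 3 cannot be read because of the ceiling of the assay: the limit of > 50000 nM in this assay, at which 2 of the 3 values shown sit.

The compounds shown leave open whether the readable number of compound 1 goes with the diethylamino end of its chain or with the amide nitrogen that joins this chain to the carbonyl carbon. A (2-(diethylamino)ethyl)oxy group or a plain ethylamino group on the same carbonyl carbon would separate these two parts.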